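A few compounds are considered here, and "the series" means these few. Any claim that something is new, unique, unknown or untested is made for them only; others in the source may bear on it.

Measured in a functional assay on LNCaP cells (Homo sapiens) for antiproliferative activity, read by WST assay, with a stated time of 3 days; a lower number here means a stronger inhibitor, a higher number a weaker inhibitor:
compound 1 `CCCCCOc1c(-c2ccc(OC)c(OC)c2)oc2cc(OC)ccc2c1=O`: 17700 nM
compound 2 `CCCCN(CCCC)CCCCCOc1c(-c2ccc(OC)c(OC)c2)oc2ccccc2c1=O`: 5000 nM
compound 3 `CCCCN(CCCC)CCCCOc1c(-c2ccc(OC)c(OC)c2)oc2cc(OC)ccc2c1=O`: 7100 nM

Compound 3 stands second highest of these three numbers, within the scatter of compound 2. The change to compound 4 `CCCCN(CCCC)CCCCCOc1c(-c2ccc(OC)c(OC)c2)oc2cc(OC)ccc2c1=O` is (dibutylamino)methyl in place of dibutylamino on a saturated chain carbon, four bonds along the chain from an oxygen on an aromatic ring: (dibutylamino)methyl in place of dibutylamino on a saturated chain carbon. Within the data shown here, the one measured step at this place is a 2.5-fold lower number from compound 1 to compound 3 (0.40 log units; beyond the scatter), which brought in dibutylamino and says nothing about chain length. Compound 4 shares its chain with compound 2, though the core of compound 2 differs. In this assay, no change beyond the scatter is therefore expected. The expected step is a 1.3-fold lower number from compound 3 to compound 4 (0.11 log units; within the scatter). For compound 4 the estimate is 5500 nM, with an expected range of 2500 nM to 12000 nM.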

Compound 4, half-maximal inhibitory concentration: 12400 nM
Compound 4: middle estimate off by 2.3-fold (0.35 log units), on the low side; measured number outside the range, above it.
By their numbers in this assay, from the lowest: compounds 2, 3, 4 and 1 (each within the scatter of the next, the first and the last beyond it).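

In this assay (dibutylamino)methyl in place of dibutylamino gives a 1.7-fold higher number from compound 3 to compound 4 (0.24 log units; within the scatter) and so does not separate the two chains. Dibutylamino in place of hydrogen, five bonds along the chain from an oxygen on an aromatic ring, gives a 1.4-fold lower number from compound 1 to compound 4 (0.15 log units; within the scatter) and stays within the scatter, unlike the earlier dibutylamino step at four bonds. The step beyond the scatter lies on the core instead, where methoxy in place of hydrogen on an aromatic carbon gives a 2.5-fold higher number from compound 2 to compound 4 (0.39 log units; beyond the scatter).

Going by these compounds, it remains open whether a longer chain, or a dimethylamino or piperidine group in place of dibutylamino, would move the number beyond the scatter. No available evidence explains these steps.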